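The compounds below may be only part of what the source reports. "The series", "measured", "known", "first", "only" and "open" are said of these compounds alone.

Working notes on the series. The shared core is shown in compound 1 `COc1ccccc1Nc1nc(SCc2cn(CC(=O)NC(=O)Nc3ccccn3)nn2)nc(-c2ccc(C(C)C)cc2)c1C#N`, which in a functional assay on ECa-109 cells (Homo sapiens) for inhibition, read by MTT assay, with a stated time of 72 h (on this read-out higher numbers stand for weaker inhibition and lower numbers for stronger inhibition), gives 8960 nM. Compound 2 `Cc1ccc(-c2nc(SCc3cn(CC(=O)NC(=O)Nc4ccccn4)nn3)nc(Nc3ccc(C(C)C)cc3)c2C#N)cc1` gives 7450 nM in this assay. Compound 3 `COc1ccc(Nc2nc(SCc3cn(CC(=O)NC(=O)Nc4ccccn4)nn3)nc(-c3ccc(C)cc3)c2C#N)cc1` gives 5870 nM in this assay. On these numbers compound 3 carries the lowest value of the three, but its gaps to compound 2 and to compound 1 both stay within the scatter, so no order among the three can be drawn. For the measured compounds named here, the one single-site step in hand, a 1.3-fold lower number from compound 2 to compound 3 (0.10 log units; within the scatter), is likewise within the scatter.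

Compound 4 `COc1ccccc1Nc1nc(SCc2cn(CC(=O)NC(=O)Nc3ccccn3)nn2)nc(-c2ccc(C)cc2)c1C#N` is not yet measured. It differs from compound 3 in one place: 2-methoxyphenyl in place of 4-methoxyphenyl on a nitrogen on an aromatic ring. Going by the values given here, no measured step moves a methoxy from one ring carbon to another, so the step from compound 2 to compound 3 bears on it only loosely, as a change at the same nitrogen-borne ring. Compound 1 and compound 4 share the 2-methoxyphenyl group on that nitrogen, and compound 1 sits within the scatter of compound 3. The expected step in this assay is therefore a 1.2-fold higher number from compound 3 to compound 4 (0.08 log units; within the scatter), none beyond the scatter. The value for compound 4 is estimated at 7000 nM, in the range 3500 nM to 14000 nM.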

Compound 4, half-maximal inhibitory concentration: 7850 nM
For compound 4 the middle estimate is 1.1-fold (0.05 log units) below the measured one, and the stated range covers the measured number.
By their numbers in this assay, from the lowest: compounds 3, 2, 4 and 1 (each within the scatter of the next).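

In this assay, for the compounds shown here, 2-methoxyphenyl in place of 4-methoxyphenyl on the nitrogen gives the first direct reading of where the methoxy sits on that ring, a 1.3-fold higher number from compound 3 to compound 4 (0.13 log units; within the scatter), so the two groups cannot be told apart here. With the same nitrogen, the swap from 4-isopropylphenyl reads a 1.1-fold higher number from compound 2 to compound 4 (0.02 log units; within the scatter), and with 2-methoxyphenyl held in place, methyl in place of isopropyl on the other ring reads a 1.1-fold lower number from compound 1 to compound 4 (0.06 log units; within the scatter), so neither change separates the compounds. Nothing measured here offers a reason for these readings.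

All the groups on that nitrogen shown so far are carbon-only aromatic rings carrying methoxy or isopropyl, so it remains open whether a carboxylic acid or an amine on that ring would move the number beyond the scatter. From the compounds shown here alone, whether an unsubstituted phenyl or a longer alkyl chain would do so also remains open.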